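Removing the amino group from compound 1

The source may hold more compounds than are shown below. What is called first, only, known or untested is meant among the compounds shown, and "the series" means these compounds.

In a functional assay on aorta (Rattus norvegicus, strain Wistar) (on this read-out lower numbers stand for stronger inhibition and higher numbers for weaker inhibition), compound 1 (`CC1(C)CN(C2=CCCC2=O)c2cc(N)ccc2S1`) gives 3980 nM, the highest of the three numbers and the weakest inhibition, with both gaps beyond the scatter. Compound 2 (`CC1CN(C2=CCCC2=O)c2cc(C(F)(F)F)ccc2S1`) gives 8.32 nM and compound 3 (`CC1(C)CSc2ccc(C(F)(F)F)cc2N1C1=CCCC1=O`) gives 66.1 nM. Compound 4 (`CC1(C)CN(C2=CCCC2=O)c2ccccc2S1`) is the next comparison: hydrogen in place of amino on an aromatic carbon. No measured step sizes this change, so the expectation rests on the values alone: compound 1 stands at 3980 nM, compound 3 at 66.1 nM, and compound 4 is expected to fall between them. A moderate step towards stronger inhibition, beyond the scatter, is expected: a 6.6-fold lower number from compound 1 to compound 4 (0.82 log units; beyond the scatter). Compound 4 is estimated at 600 nM, within an expected range of 150 nM to 2400 nM.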

Compound 4, half-maximal inhibitory concentration: 724 nM
The estimate for compound 4 lay 1.2-fold (0.08 log units) below the measured number; the measured number falls inside the stated range.
By their numbers in this assay, from the lowest: compound 2; then compound 3; then compound 4; then compound 1.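

In this assay, hydrogen in place of amino on this aromatic carbon gives a 5.5-fold lower number from compound 1 to compound 4 (0.74 log units; beyond the scatter), so inhibition in this series does not depend on the amino group at this position. Compound 4 at 724 nM still stands above compound 3 at 66.1 nM, which carries trifluoromethyl on the same carbon, so the number at this carbon rises from trifluoromethyl through hydrogen to amino. Nothing available explains this order.

Open, going by these compounds, is where other groups at this carbon, such as chlorine, a nitrile or a methoxy group, would fall in that order.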